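Replacing an Aryl Amino Group with Dimethylamino

The compounds below may be only part of what the source reports. "The series", "measured", "known", "first", "only" and "open" are said of these compounds alone.

Compound 1 `Cn1c(=O)c2nc(-c3cccc(F)c3)[nH]c2n(C)c1=O`: 4 nM
Compound 2 `Cn1c(=O)c2nc(-c3ccc(Cl)cc3)[nH]c2n(C)c1=O`: 0.8 nM
Compound 3 `Cn1c(=O)c2nc(-c3cccc(N)c3)[nH]c2n(C)c1=O`: 10 nM

In an assay for binding affinity to adenosine receptor A1 (Bos taurus) (on this read-out higher numbers stand for weaker inhibition and lower numbers for stronger inhibition), compound 3 stands highest of the three numbers, nearest to compound 1 and furthest from compound 2. Going by the values given here, the one measured step at this ring position is a 2.5-fold higher number from compound 1 to compound 3 (0.40 log units; beyond the scatter), a modest shift. Compound 4 `CN(C)c1cccc(-c2nc3c(=O)n(C)c(=O)n(C)c3[nH]2)c1` is the next variant: dimethylamino in place of amino on an aromatic carbon. Among the compounds with values here, no measured pair shows what methylating this amine does, so the only bearing comes from that single modest step, which does not involve the same groups. The change is therefore expected to move this assay by no more than a modest step, in either direction, amounting to a 1.5-fold higher number from compound 3 to compound 4 (0.18 log units; within the scatter). Compound 4 is accordingly estimated at 15 nM, with a range from 4 nM to 60 nM.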

Compound 4, half-maximal inhibitory concentration: 80 nM
Compound 4: the middle estimate sits 5.3-fold (0.73 log units) below what was measured; the measured number lies above the stated range.
By their numbers in this assay, from the lowest: compound 2; then compound 1; then compound 3; then compound 4.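

At this ring position, this assay now shows an 8.0-fold higher number from compound 3 to compound 4 (0.90 log units; beyond the scatter), so dimethylamino, with no hydrogen-bond donor, gives a higher number than amino, which has one. Measured from the fluoro group, the change amounts to a 20-fold higher number from compound 1 to compound 4 (1.30 log units; beyond the scatter), the widest step at this position, and the numbers rise from fluoro through amino to dimethylamino. No measured evidence bears on why the number rises with this change. Whether a single methyl on the amine, as in methylamino, already accounts for part of this step stays open. So does how a hydroxyl or methoxy group would read at the same place.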